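A few compounds are considered here, and "the series" means these few. Any claim that something is new, unique, unknown or untested is made for them only; others in the source may bear on it.

Measured so far in a functional assay on MCF7 cells (Homo sapiens) for cytotoxicity, read by MTT assay, with a stated time of 48 h; on this read-out higher numbers stand for weaker inhibition and lower numbers for stronger inhibition: compound 1 `COc1ccc(CNC(=O)CSc2nc3ccc(NC(=O)c4ccccc4OC)cc3s2)cc1` gives 9300 nM; compound 3 `COc1ccc(CNC(=O)CSc2nc3ccc(NC(=O)CCl)cc3s2)cc1` gives 5100 nM. Compound 2 `COc1ccc(CNC(=O)CSc2nc3ccc(NC(=O)c4ccc([N+](=O)[O-])cc4)cc3s2)cc1` reaches only the limit of this assay, > 100000 nM.

Compound 1 holds the highest of the two numbers, with compound 3 nearest: a 1.8-fold lower number from compound 1 to compound 3 (0.26 log units; within the scatter). The remaining steps, an at least 10-fold higher number from compound 1 to compound 2 (1.03 log units; beyond the scatter) and an at least 19-fold lower number from compound 2 to compound 3 (1.29 log units; beyond the scatter), are large, and compound 2 sits at the limit of > 100000 nM in this assay, at which 1 of the 3 values shown sits.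

Compound 4 `COc1ccccc1C(=O)Nc1ccc2nc(SCC(=O)NCc3ccccc3)sc2c1` differs from compound 1 by hydrogen in place of methoxy on an aromatic carbon. For the measured compounds named here, every measured step exchanges the group on the carbonyl carbon; none touches the six-membered aromatic ring of carbon only, so no measured step bears directly on this change. A step of no more than the scatter is expected, a 1.0-fold higher number from compound 1 to compound 4 (0.01 log units; within the scatter). Compound 4 is therefore estimated at 9500 nM, range 4000 nM to 25000 nM.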

Compound 4, half-maximal inhibitory concentration: 17200 nM
Estimate against measurement, compound 4: 1.8-fold (0.26 log units) below; the measured number falls inside the stated range.
By their numbers in this assay, from the lowest: compounds 3, 1 and 4 (each within the scatter of the next, the first and the last beyond it). At a limit, above all of these: compound 2.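

For the compounds shown here, compound 4 gives the first reading at the 4-methoxybenzyl end of the series, where all earlier steps exchanged the group on the carbonyl carbon. In this assay, hydrogen in place of methoxy gives a 1.8-fold higher number from compound 1 to compound 4 (0.27 log units; within the scatter), so the methoxy is not shown to be needed for the activity of compound 1. Nothing on hand bears on this step.

Open, going by these compounds, is how an amine, a carboxylic acid or a longer chain would read at this aromatic carbon. Also open, on these data alone, is whether the same exchange reads alike with the chloromethyl group of compound 3.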